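Swapping an octyl chain for a bromobenzyl group

A few compounds are considered here, and "the series" means these few. Any claim that something is new, unique, unknown or untested is made for them only; others in the source may bear on it.

Measured compounds:
compound 1 `CCCCCCCCn1cc(/C=C/C(=O)c2ccc(NC(=O)CN3CCN(c4ccccc4F)CC3)cc2)nn1` gives 47100 nM in a functional assay on A549 cells (Homo sapiens) for inhibition, read by MTT assay; a lower number here means a stronger inhibitor, a higher number a weaker inhibitor;
compound 2 `CCCCCCCCn1cc(/C=C/C(=O)c2ccc(N)cc2)nn1` gives 26900 nM in this assay;
compound 3 `O=C(CN1CCN(c2ccccc2F)CC1)Nc1ccc(C(=O)/C=C/c2cn(Cc3ccc(Br)cc3)nn2)cc1` gives 14700 nM in this assay.

Compound 1 and compound 3 share a core and differ only by 4-bromophenyl in place of heptyl on a saturated chain carbon bound to an aromatic nitrogen. That single change gave a 3.2-fold lower number from compound 1 to compound 3 (0.51 log units; beyond the scatter). The values of compound 2 lie within the scatter of those of compound 1 and of compound 3, so no order among them is drawn. Compound 2 carries a smaller core than compound 1; the difference between the two cores is not broken down here.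

Compound 4 `Nc1ccc(C(=O)/C=C/c2cn(Cc3ccc(Br)cc3)nn2)cc1` has not yet been measured in this assay. It stands to compound 2 as compound 3 stands to compound 1, differing by 4-bromophenyl in place of heptyl on a saturated chain carbon bound to an aromatic nitrogen, the same change. Compound 4 is expected to show a 2.8-fold lower number from compound 2 to compound 4 (0.45 log units; beyond the scatter), a step close to the earlier one, resting on the step from compound 1 to compound 3 and the value of compound 2 at 26900 nM, with the caveat that the change is seen only once and on a different core. For compound 4 the estimate is 9500 nM, expected to fall between 3500 nM and 26000 nM.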

Compound 4, half-maximal inhibitory concentration: 15800 nM
The estimate for compound 4 lay 1.7-fold (0.22 log units) below the measured number; low and high end bracket the measured number.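

On the smaller core, the octyl to 4-bromobenzyl change gave a 1.7-fold lower number from compound 2 to compound 4 (0.23 log units; within the scatter) in this assay, so the two values cannot be told apart. Set beside the step on the larger core, this step does not differ from it beyond what repeated measurements would produce: the same change on two cores in this assay, a 3.2-fold lower number (0.51 log units; beyond the scatter) from compound 1 to compound 3 and a 1.7-fold lower number (0.23 log units; within the scatter) from compound 2 to compound 4, 1.9-fold (0.27 log units) apart, within the scatter of two such steps The change therefore carried from one core to the other with no detectable difference in the size of its step, but this does not show that it has a real effect on the smaller core, and two cores are too few to support a rule for the series.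

The compounds shown leave open whether other groups at this place, such as an unsubstituted benzyl, a 4-chlorobenzyl or a shorter butyl chain, would give similar values. They also leave open how the change behaves when the amine of the smaller core carries a simple acetyl group.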